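Shortening the side chain of compound 3 to propyl

The source may report more compounds than this note shows. Statements on the series, on what has been measured and on what is new or still open speak of the compounds shown alone.

Of the compounds shown here, three on a shared core have so far been read in a functional assay on A549 cells (Homo sapiens) for antiproliferative activity, read by MTT assay, with a stated time of 48 h (on this read-out lower numbers stand for stronger inhibition and higher numbers for weaker inhibition), as follows. Compound 1 `CN(C)CCn1c(N)c(-c2nc3ccccc3[nH]2)c2nc(C#N)c(C#N)nc21` shows > 50000 nM here, which is a limit and not a number. Compound 2 `CCN(CC)CCn1c(N)c(-c2nc3ccccc3[nH]2)c2nc(C#N)c(C#N)nc21` likewise shows the limit > 50000 nM and gives no number. Within the data shown here, compound 3 `CN1CCN(CCn2c(N)c(-c3nc4ccccc4[nH]3)c3nc(C#N)c(C#N)nc32)CC1` gives 40500 nM as the only true number of the three.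

Compound 4 `CCCn1c(N)c(-c2nc3ccccc3[nH]2)c2nc(C#N)c(C#N)nc21` has not yet been measured. It carries propyl where compound 3 carries 2-(4-methylpiperazin-1-yl)ethyl: methyl in place of 4-methylpiperazin-1-yl on a saturated chain carbon, two bonds along the chain from an aromatic nitrogen.

Three measured steps alter the group at this same place. Among the measured compounds shown here, the first is a step that the two limits leave unreadable from compound 1 to compound 2 and gives no size. The other two are an at least 1.2-fold lower number from compound 1 to compound 3 (0.09 log units; that floor lies within the scatter) and an at least 1.2-fold lower number from compound 2 to compound 3 (0.09 log units; that floor lies within the scatter) and neither floor goes beyond the scatter. None of them removes the ring as this change does, so they guide only loosely.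

No step beyond the scatter is therefore expected in this assay and the expected move is a 1.2-fold higher number from compound 3 to compound 4 (0.09 log units; within the scatter) toward a higher number. A report of only a limit is quite possible. For compound 4 the estimate is 50000 nM with 20000 nM as its lower end and 120000 nM as its upper end.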

Compound 4, half-maximal inhibitory concentration: 1970 nM
Compound 4: middle estimate off by 25-fold (1.40 log units), on the high side, and the stated range ends above it.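

In this assay, among these compounds, this position proved far more responsive than the earlier compounds could show, since the change at the saturated chain carbon gives a 21-fold lower number from compound 3 to compound 4 (1.31 log units; beyond the scatter). Measured against the two compounds with open-chain amines, the same replacement of the amino group by methyl gives an at least 25-fold lower number from compound 2 to compound 4 (1.40 log units; beyond the scatter) and an at least 25-fold lower number from compound 1 to compound 4 (1.40 log units; beyond the scatter), so all three compounds with an amine-bearing chain lie on the weaker side of the propyl compound, with none going against this. Compound 1 and compound 2 each show only a limit, which makes their two steps floors and leaves their true sizes unknown: the limit of > 50000 nM in this assay, at which 2 of the 4 values shown sit.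

Compound 4 is the only compound shown whose chain carries no amine, and it leaves open whether the gain follows from losing the amine alone or depends on the propyl chain itself. A longer butyl chain, a shorter ethyl chain or a chain ending in a hydroxyl group would be needed to tell how far this effect extends, and a morpholine ring at the chain end would test whether any ring there behaves like 4-methylpiperazin-1-yl.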